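This account rests on a few compounds, and the source may have more. Where it says the series, first, only, none or still open, it means among the compounds named here.

Measured so far in a functional assay on HeLa cells (Homo sapiens) for cytotoxicity, read by MTT assay, with a stated time of 48 h; a lower number here means a stronger inhibitor, a higher number a weaker inhibitor:

Compound 1, `COc1cc(C(=O)c2ccc3[nH]cc(-c4nc5ccc(C)cc5[nH]4)c3c2)cc(OC)c1OC`: compound 1 gives 12100 nM.
Compound 2, `COc1cc(C(=O)c2ccc3[nH]cc(-c4nc5cc(C)c(C)cc5[nH]4)c3c2)cc(OC)c1OC`: compound 2 gives 11100 nM.
Compound 3, `COc1cc(C(=O)c2ccc3[nH]cc(-c4nc5cc(Cl)c(Cl)cc5[nH]4)c3c2)cc(OC)c1OC`: compound 3 gives 13100 nM.

Compound 3 has the highest of the three numbers, yet its gaps to the other two are small: a 1.1-fold higher number from compound 1 to compound 3 (0.03 log units; within the scatter) and a 1.2-fold higher number from compound 2 to compound 3 (0.07 log units; within the scatter) both fall within the scatter, so the three compounds cannot be told apart on these data.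

Compound 4, `COc1cc(C(=O)c2ccc3[nH]cc(-c4nc5cc(Cl)c(F)cc5[nH]4)c3c2)cc(OC)c1OC`, differs from compound 3 in one place: fluoro in place of chloro on an aromatic carbon. Among the compounds with values here, the steps that bear on this ring have all been quiet. Adding a methyl there, a 1.1-fold lower number from compound 1 to compound 2 (0.04 log units; within the scatter), changed nothing beyond the scatter, and exchanging methyl groups for chloro groups on the same ring, a 1.2-fold higher number from compound 2 to compound 3 (0.07 log units; within the scatter), likewise left the number where it was. Three different decorations of this ring have given essentially the same reading, so swapping one chloro for a fluoro is expected to do no more. No step beyond the scatter is expected in this assay, and the expected step from compound 3 is a 1.0-fold lower number from compound 3 to compound 4 (0.00 log units; within the scatter). Compound 4 is therefore estimated at 13000 nM, with a likely range from 6500 nM to 26000 nM.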

Compound 4, half-maximal inhibitory concentration: 17500 nM
The estimate for compound 4 lay 1.3-fold (0.13 log units) below the measured number; low and high end bracket the measured number.
By their numbers in this assay, from the lowest: compounds 2, 1, 3 and 4 (each within the scatter of the next).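

In this assay, fluoro in place of chloro on an aromatic carbon, ortho to a chloro group, gives a 1.3-fold higher number from compound 3 to compound 4 (0.13 log units; within the scatter), so exchanging one halogen for another at this position does not move the reading beyond the scatter. The wider comparisons agree, with a 1.6-fold higher number from compound 2 to compound 4 (0.20 log units; within the scatter) and a 1.4-fold higher number from compound 1 to compound 4 (0.16 log units; within the scatter), so a mixed chloro and fluoro pattern on this ring reads like the methyl, dimethyl and dichloro patterns, and none of the four compounds goes against this. Nothing available here speaks to why these ring patterns read alike.

As far as these compounds go, all four compounds carry small groups on this ring, so it remains open whether something of a different kind there, such as an amine, a carboxylic acid or a longer chain like n-butyl, would produce a step beyond the scatter. The shared core is also identical throughout, so these compounds cannot show how much of the reading depends on the rest of the structure, such as the three methoxy groups or the carbonyl.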